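The source may report more compounds than this note shows. Statements on the series, on what has been measured and on what is new or still open speak of the compounds shown alone.

Measured compounds in a functional assay on the whole organism (strain Swiss) with Mus musculus as the target, in the maximal electroshock model, with a stated time of 0.25 h, at a dose of 300 mg/kg by the intraperitoneal route; a lower number here means a weaker effect, a higher number a stronger effect of the compound at the dose given:
compound 1, `CCC(C(=O)N1CCN(c2ccccc2Cl)CC1)N1C(=O)CCC1=O`, gives 50%
compound 2, `CCC(C(=O)N1CCN(c2cccc(OC)c2)CC1)N1C(=O)CCC1=O`, gives 25%

Compound 2 stands lowest of the two numbers; its nearest neighbour is compound 1, whose value in this assay is 50%, beyond the scatter above compound 2. For the measured compounds named here, the single measured step, a number 25 percentage points lower from compound 1 to compound 2 (beyond the scatter), accompanies 3-methoxyphenyl in place of 2-chlorophenyl on an amine nitrogen in a ring.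

Compound 3, `CCC(C(=O)N1CCN(c2cccc(F)c2)CC1)N1C(=O)CCC1=O`, remains to be measured in this assay. It differs from compound 2 by fluoro in place of methoxy on an aromatic carbon. The same difference, cut one bond further out, reads 3-methoxyphenyl to 3-fluorophenyl.

Going by the values given here, no measured step exchanges methoxy for fluoro at one place; the only step known alters both the group and where it sits on the ring, so none bears directly on this change. Without a step to lean on, compound 3 is expected to stay near compound 2, with a step of a number 5 percentage points higher from compound 2 to compound 3 (within the scatter) that is not expected to exceed the scatter. The estimate for compound 3 in this assay is therefore 30%, in a range from 10% to 55%.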

Compound 3, a percentage reported as activity, at one dose (the size of the read-out at that dose, not a potency): 75%
Compound 3: middle estimate off by 45 percentage points, on the low side; the whole stated range lies below it.
By their numbers in this assay, from the lowest: compound 2; then compound 1; then compound 3.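

In this assay, the exchange of methoxy for fluoro on an aromatic carbon, meta to a large group, comes with a number 50 percentage points higher from compound 2 to compound 3 (beyond the scatter) and leaves the rest of the structure unchanged, so this position clearly responds to the group it carries. The earlier step could not show this, as it altered the group and its place on the ring together. The 3-fluorophenyl group also reads higher than 2-chlorophenyl, with a number 25 percentage points higher from compound 1 to compound 3 (beyond the scatter) making compound 3 the highest of the three, although this step again changes group and place at once, and nothing available explains the size of either step.

Going by these compounds, it remains open whether fluoro is unusual at this position or whether a methyl, a hydroxyl or a chloro group there would read just as high. The compounds shown also do not separate the effect of the group from that of its place on the ring, a question that 2-fluorophenyl or 3-chlorophenyl on the same core would address, and a read-out at one dose tells only of a stronger or weaker effect at that dose.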